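This account rests on a few compounds, and the source may have more. Where it says the series, first, only, none or still open, it means among the compounds named here.

In an assay on isolated protein for inhibition of protein kinase C theta type (Homo sapiens), read by TR-FRET, with a stated time of 2 h (on this read-out lower numbers stand for stronger inhibition and higher numbers for weaker inhibition), compound 1 `CC(C)(F)c1ncncc1CNc1cc(N[C@H]2CC[C@@H](O)CC2)c(C#N)cn1` gives 32 nM, compound 2 `N#Cc1cnc(NCc2cncnc2-c2ccccc2)cc1N[C@H]1CC[C@@H](O)CC1` gives 90 nM, and compound 3 `COc1ncncc1CNc1cc(N[C@H]2CC[C@@H](O)CC2)c(C#N)cn1` gives 800 nM, the highest of the three numbers: the step of a 25-fold higher number from compound 1 to compound 3 (1.40 log units; beyond the scatter) and the step of an 8.9-fold higher number from compound 2 to compound 3 (0.95 log units; beyond the scatter) both lie beyond the scatter. Compound 4 `CC(C)(C)Oc1ncncc1CNc1cc(N[C@H]2CC[C@@H](O)CC2)c(C#N)cn1` differs from compound 3 by tert-butyl in place of methyl on an oxygen on an aromatic ring. Going by the values given here, no measured step changes this oxygen-bound group, so the two steps above are only loosely related; both show that moving away from methoxy at this end of the shared core lowered the number, one modestly and one largely. A lower number is therefore expected for compound 4, but as a modest step, a 4.0-fold lower number from compound 3 to compound 4 (0.60 log units; beyond the scatter), estimated at 200 nM within a range of 50 nM to 800 nM.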

Compound 4, half-maximal inhibitory concentration: 200 nM
Beside the measured number, compound 4's estimate shows no gap at the digits printed; low and high end bracket the measured number.
By their numbers in this assay, from the lowest: compound 1; then compound 2; then compound 4; then compound 3.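

In this assay, tert-butyl in place of methyl on an oxygen on an aromatic ring gives a 4.0-fold lower number from compound 3 to compound 4 (0.60 log units; beyond the scatter), so the number at this position depends on the group carried by the oxygen, not just on the oxygen being there. Tert-butoxy still falls short of the two groups attached through carbon, with a 2.2-fold higher number from compound 2 to compound 4 (0.35 log units; beyond the scatter) and a 6.3-fold higher number from compound 1 to compound 4 (0.80 log units; beyond the scatter). Nothing available here explains these steps. Still open, from the compounds shown here alone, is how an ethyl or isopropyl group on the same oxygen, or an amine in place of the tert-butoxy, would read.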